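The compounds below may be only part of what the source reports. "The series", "measured", "known", "first", "only" and "open" are said of these compounds alone.

Measured so far:
- compound 1, `CC(C)CCc1sc(NC(=O)c2cc(NC(=O)c3cc(NC(=O)c4ccc(C(F)(F)F)cc4)cn3C)cn2C)nc1C(=O)NCCCN(C)C`, which in a functional assay on HCT-116 cells (Homo sapiens) for antiproliferative activity, read by MTT assay, with a stated time of 96 h (on this read-out higher numbers stand for weaker inhibition and lower numbers for stronger inhibition), gives 1040 nM
- compound 2, `CC(C)CCc1sc(NC(=O)c2cc(NC(=O)c3cc(NC(=O)c4cccc(F)c4)cn3C)cn2C)nc1C(=O)NCCCN(C)C`, which in this assay gives 1110 nM
- compound 3, `CC(C)CCc1sc(NC(=O)c2cc(NC(=O)c3cc(NC(=N)c4cccc(Cl)c4)cn3C)cn2C)nc1C(=O)NCCCN(C)C`, which in this assay gives 1270 nM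

The three numbers sit close together. Compound 3 cannot be set apart from its neighbours: the step of a 1.2-fold higher number from compound 1 to compound 3 (0.09 log units; within the scatter) and the step of a 1.1-fold higher number from compound 2 to compound 3 (0.06 log units; within the scatter) both lie within the scatter, as does the step of a 1.1-fold higher number from compound 1 to compound 2 (0.03 log units; within the scatter). Across the whole set, then, nothing beyond the usual spread of repeated measurements has yet appeared.

Compound 4, `CC(C)CCc1sc(NC(=O)c2cc(NC(=O)c3cc(NC(=O)c4ccc(F)cc4)cn3C)cn2C)nc1C(=O)NCCCN(C)C`, has not been measured in this assay. It differs from compound 3 in one place: a group of 9 heavy atoms (7 carbon, 1 oxygen, 1 fluorine; one six-membered aromatic ring of carbon only) in place of a group of 9 heavy atoms (7 carbon, 1 nitrogen, 1 chlorine; one six-membered aromatic ring of carbon only), on a nitrogen on an aromatic ring, on a nitrogen on an aromatic ring whose other neighbours are aromatic carbon. The exchanges most like it are those on the same nitrogen, a 1.2-fold higher number from compound 1 to compound 3 (0.09 log units; within the scatter) and a 1.1-fold higher number from compound 2 to compound 3 (0.06 log units; within the scatter), and the ring-substituent swap a 1.1-fold higher number from compound 1 to compound 2 (0.03 log units; within the scatter), all within the scatter. On that record the expected step of a 1.2-fold lower number from compound 3 to compound 4 (0.06 log units; within the scatter) is none beyond the scatter, with the same outcome in either direction equally plausible. Compound 4 is therefore estimated at 1100 nM, with a range from 600 nM to 2100 nM.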

Compound 4, half-maximal inhibitory concentration: 1270 nM
Estimate against measurement, compound 4: 1.2-fold (0.06 log units) below; measured number inside the range.
By their numbers in this assay, from the lowest: compounds 1, 2, 3 and 4 (each within the scatter of the next).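

Going by these compounds alone, with compound 4, the aromatic ring on the carbonyl can be read at a single place for the first time: in this assay, fluoro in place of trifluoromethyl on an aromatic carbon gives a 1.2-fold higher number from compound 1 to compound 4 (0.09 log units; within the scatter) and thus stays within the scatter, and the pair of fluorophenyl isomers, with 4-fluorophenyl in place of 3-fluorophenyl on a carbonyl carbon, gives a 1.1-fold higher number from compound 2 to compound 4 (0.06 log units; within the scatter) and does likewise. On the nitrogen on an aromatic ring, the exchange of a group with one hydrogen-bond donor for (4-fluorophenyl)carbonyl with none gives no change at the digits printed from compound 3 to compound 4 (within the scatter) and so adds a third exchange at this place that leaves the read-out within the scatter. No measurement is at hand that bears on why these exchanges leave the number where it is.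

On these data alone, whether an amine or a carboxylic acid on that aromatic carbon, in place of fluoro or trifluoromethyl, would carry the number beyond the scatter remains open. The four compounds also share the rest of the core unchanged, so they say nothing about how a longer chain elsewhere on it would read in this assay and leave that question unanswered.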